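The source may hold more compounds than are shown below. What is called first, only, known or untested is meant among the compounds shown, and "the series" means these compounds.

Working notes on the series. In a functional assay on SW-620 cells (Homo sapiens) for cytotoxicity, read by sulforhodamine B assay, with a stated time of 48 h (on this read-out lower numbers stand for stronger inhibition and higher numbers for weaker inhibition), compound 1 (`C[C@H]1CC[C@@H]2[C@@H](OC(=O)[C@]23CC(c2ccc(Cl)cc2)=NO3)[C@]2(C)C(=O)C=C[C@@]12O`) gives 51000 nM and compound 2 (`COc1cc(C2=NO[C@]3(C2)C(=O)O[C@@H]2[C@H]3CC[C@H](C)[C@]3(O)C=CC(=O)[C@@]23C)ccc1O`) gives 88000 nM. Among the measured compounds shown here, these are the only two numbers so far, and compound 2 cannot be separated from compound 1 on them. Compound 3 (`C[C@H]1CC[C@@H]2[C@@H](OC(=O)[C@]23CC(c2ccccc2Cl)=NO3)[C@]2(C)C(=O)C=C[C@@]12O`) is not yet measured. The change from compound 2 is 2-chlorophenyl in place of 4-hydroxy-3-methoxyphenyl on a carbon with a double bond to nitrogen, with 2-chlorophenyl in place of 4-hydroxy-3-methoxyphenyl on a carbon with a double bond to nitrogen. For the measured compounds named here, one measured step bears on this, at the same place: a 1.7-fold higher number from compound 1 to compound 2 (0.24 log units; within the scatter), with 4-hydroxy-3-methoxyphenyl in place of 4-chlorophenyl. Going by the values given here, no measured step covers 2-chlorophenyl itself. Among the compounds with values here, with only that small step as a guide, no change beyond the scatter is expected in this assay, and no direction can be assigned. The expected size is a 1.4-fold lower number from compound 2 to compound 3 (0.13 log units; within the scatter). Compound 3 is estimated at 65000 nM, with a range of 28000 nM to 140000 nM.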

Compound 3, half-maximal inhibitory concentration: 9000 nM
The estimate for compound 3 lay 7.2-fold (0.86 log units) above the measured number, and the stated range ends above it.
By their numbers in this assay, from the lowest: compound 3; then compounds 1 and 2 (each within the scatter of the next).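

In this assay, this position on the carbon with a double bond to nitrogen proves able to move the read-out: 2-chlorophenyl in place of 4-hydroxy-3-methoxyphenyl gives a 9.8-fold lower number from compound 2 to compound 3 (0.99 log units; beyond the scatter), a step beyond the scatter, unlike the earlier exchange. The presence of chlorine alone does not set the value, since 2-chlorophenyl in place of 4-chlorophenyl gives a 5.7-fold lower number from compound 1 to compound 3 (0.75 log units; beyond the scatter), with the rest of the molecule unchanged. No measurement at hand accounts for either step.

Going by these compounds, whether the lower number belongs to chlorine itself or to any group at that place on the phenyl ring stays open, and 2-methylphenyl, 2-methoxyphenyl or 2-aminophenyl would separate these readings. The compounds shown also leave open how 3-chlorophenyl or 2,6-dichlorophenyl would compare with 2-chlorophenyl on the same core.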